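Swapping an acetyl for a silicon group on compound 1

The source may report more compounds than this note shows. Statements on the series, on what has been measured and on what is new or still open speak of the compounds shown alone.

Among the compounds with values here, in a functional assay on P388 cells (Mus musculus) for cytotoxicity, read by sulforhodamine B assay (a lower number here means that less compound is needed, a higher number that more compound is needed for the effect), compound 1 (`C=C1CC[C@@H]2[C@](C)(COC(C)=O)[C@H](OC(C)=O)CC[C@@]2(C)[C@@H]1C/C=C1/C(=O)OC[C@H]1OC(C)=O`) gives 1.4 uM and holds the higher of the two numbers measured so far. Compound 2 (`C=C1CC[C@@H]2[C@](C)(CO[Si](c3ccccc3)(c3ccccc3)C(C)(C)C)[C@H](OC(C)=O)CC[C@@]2(C)[C@@H]1C/C=C1/C(=O)OC[C@H]1O`) gives 0.5 uM on the same read-out, and the gap between the two lies beyond the scatter. With only these two values, no structural trend can be drawn.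

Compound 3 (`C=C1CC[C@@H]2[C@](C)(CO[Si](C(C)C)(C(C)C)C(C)C)[C@H](OC(C)=O)CC[C@@]2(C)[C@@H]1C/C=C1/C(=O)OC[C@H]1OC(C)=O`) has not yet been measured. Its difference from compound 1 is a group of 10 heavy atoms (9 carbon, 1 silicon; no ring) in place of a group of 3 heavy atoms (2 carbon, 1 oxygen; no ring), on an oxygen on a saturated carbon and takes away an acetyl, with a group of 9 carbon and 1 silicon entering on an oxygen on a saturated carbon. The core of compound 1 is otherwise kept.

Within the data shown here, compound 2 also carries a silicon-bearing group on such an oxygen, and at 0.5 uM it is the only guide available. That is thin support, so a modest move toward a lower number in this assay is expected, rather than a large one. The estimated step is a 2.0-fold lower number from compound 1 to compound 3 (0.30 log units; within the scatter) and would sit near the edge of the scatter. The estimate for compound 3 is 0.7 uM with an expected range of 0.25 uM to 2 uM on this read-out.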

Compound 3, concentration for half-maximal effect: 1.41 uM
Beside the measured number, compound 3's estimate is 2.0-fold (0.30 log units) below it, within the range that was stated.
By their numbers in this assay, from the lowest: compound 2; then compounds 1 and 3 (each within the scatter of the next).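

In this assay the acetyl on an oxygen on a saturated carbon gives way to a group of 10 heavy atoms (9 carbon, 1 silicon; no ring) with a 1.0-fold higher number from compound 1 to compound 3 (0.00 log units; within the scatter) as the step between them. Within the data shown here, this is the only comparison so far that rests on a single place, and it shows that, with this replacement, the acetyl at this position is not needed to keep the cytotoxicity read-out within the scatter of compound 1, even though the entering group is much larger. No measured property in hand bears on this result, so the data give no account of it.

Compound 2 differs from compound 1 in more than one place, so the number of compound 2 at 0.5 uM cannot be assigned to any one change, and the role of its silicon-bearing group and its free hydroxyl remains unresolved. Also open, as far as these compounds go, is whether the position accepts groups of another kind, such as a free hydroxyl, an amine or a benzoyl ester, as readily as it accepts the silicon-bearing group of compound 3.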